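Solubility notes: tetrahydroquinolinyl in place of pyrrolidinyl

The source may report more compounds than this note shows. Statements on the series, on what has been measured and on what is new or still open speak of the compounds shown alone.

Compound 1 `COc1ccc2[nH]c(C(=O)N3CC(=O)N(Cc4ccccc4)[C@@H](CN4CCCC4)C3)cc2c1` is the starting point for this step. In a physicochemical assay for solubility, read by spectrophotometry, in phosphate buffer, with a stated time of 2 h, at pH 7.4 (a lower number here means a less soluble compound, a higher number a more soluble compound), compound 1 gives > 25000 nM, which is a limit of the assay and not a number. Where compound 1 stands among the measured values is therefore known only as a limit or a range, as the evidence shows: the limit of > 25000 nM in this assay, at which 1 of the 2 values shown sits. Compound 2 `COc1ccc2[nH]c(C(=O)N3CC(=O)N(c4ccccc4)[C@@H](Cc4ccccc4)C3)cc2c1` is the other measured member of the series; in this assay compound 2 gives 36100 nM. Among the measured compounds shown here, no two measured compounds differ in a single place, so no measured step exists to lean on.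

Compound 3 `COc1ccc2[nH]c(C(=O)N3CC(=O)N(Cc4ccccc4)[C@@H](CN4CCCc5ccccc54)C3)cc2c1` has not yet been measured. It differs from compound 1 by 1,2,3,4-tetrahydroquinolin-1-yl in place of pyrrolidin-1-yl on a saturated chain carbon bound to a saturated ring carbon.

The expected change in this assay is a decrease that goes beyond the usual scatter, estimated as an at least 3.1-fold lower number from compound 1 to compound 3 (0.49 log units; beyond the scatter). Since compound 1 sits at a limit, the true size of that step cannot be fixed from the numbers shown, and the estimate carries a wide range. For compound 3 the expected solubility in this assay is 8000 nM, estimated to lie between 2500 nM and 25000 nM.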

Compound 3, solubility: 8500 nM
The estimate for compound 3 lay 1.1-fold (0.03 log units) below the measured number; measured number inside the range.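

In this assay the series now holds its first step in a single place, an at least 2.9-fold lower number from compound 1 to compound 3 (0.46 log units; beyond the scatter), so 1,2,3,4-tetrahydroquinolin-1-yl in place of pyrrolidin-1-yl, on a saturated chain carbon bound to a saturated ring carbon, moves the number beyond the scatter. In this assay compound 1 gives > 25000 nM, a limit of the assay and not a number, so this step fixes only a minimum size: the limit of > 25000 nM in this assay, at which 1 of the 3 values shown sits. With the new group, compound 3 gives 8500 nM in this assay, a number that can serve as a firm reference for further changes at this position.

Which part of the entering group carries the step stays open, since the six-membered non-aromatic ring and the fused aromatic ring of carbon only arrive together in compound 3. A piperidine or a morpholine on the same chain carbon would separate the ring size from the aromatic ring, and an N-methylaniline would test the aromatic ring without the fused ring.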